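Exchanging One Halogenated Phenyl Group for Another

The compounds below may be only part of what the source reports. "The series", "measured", "known", "first", "only" and "open" are said of these compounds alone.

In a functional assay on Caco-2 cells (Homo sapiens) for inhibition, read by MTT assay, with a stated time of 48 h, tested at 10 uM (on this read-out higher numbers stand for more inhibition of growth at the one concentration tested and lower numbers for less inhibition of growth), compound 1 (`Cc1cc(=O)c2c(O)cc(OCc3ccccc3Br)c([C@H]3CCN(C)C[C@H]3O)c2o1`) gives 35% and compound 2 (`Cc1oc2c([C@H]3CCN(C)C[C@H]3O)c(O)cc(O)c2c(=O)c1C(O)c1ccccc1Br`) gives 7% while compound 3 (`CN1CC[C@H](c2c(O)cc(O)c3c(=O)cc(/C=C/c4c(F)c(F)c(F)c(F)c4F)oc23)[C@H](O)C1`) reaches 59% and stands highest of the three, beyond the usual scatter against both others. Compound 4 (`CN1CC[C@H](c2c(O)cc(O)c3c(=O)cc(/C=C/c4ccccc4Cl)oc23)[C@H](O)C1`) differs from compound 3 in one place: 2-chlorophenyl in place of 2,3,4,5,6-pentafluorophenyl on a double-bonded chain carbon bound to a double-bonded chain carbon. Within the data shown here, no measured pair shows this kind of exchange, so any forecast is rough. Among the measured compounds shown here, compound 3 with 59% tops only three numbers, which makes a modest fall likelier than a further rise. The expected move is a number 11 percentage points lower from compound 3 to compound 4 (beyond the scatter) in this assay and it may lie close to the scatter. For compound 4 the estimated value is 48% with an expected range of 28% to 66% around it.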

Compound 4, percent growth inhibition at one concentration: 65%
Compound 4: the middle estimate sits 17 percentage points below what was measured; the measured number falls inside the stated range.
By their numbers in this assay, from the lowest: compound 2; then compound 1; then compounds 3 and 4 (each within the scatter of the next).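

In this assay, putting 2-chlorophenyl in place of 2,3,4,5,6-pentafluorophenyl gives a number 6 percentage points higher from compound 3 to compound 4 (within the scatter), so this exchange does not separate the two compounds. On a double-bonded chain carbon bound to a double-bonded chain carbon, the read-out stays level whether the halogenated phenyl group has 11 heavy atoms or 7. No measurement here says why the two groups perform alike. Going by these compounds, whether a plain phenyl ring would hold this level remains open. So does the outcome with an amine or a carboxylic acid in that place.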